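Swapping the amine on a long-chain pyridinol core

This account rests on a few compounds, and the source may have more. Where it says the series, first, only, none or still open, it means among the compounds named here.

Compound 1 `CCCCCCCCCCCCCCCCc1c(C)c(N(C)C)nc(C)c1O` is one of three compounds tested in a functional assay on cells (Lymphocyte), read by a luciferase reporter and ATP content, with a stated time of 48 h, tested at 25 uM (on this read-out lower numbers stand for a stronger effect and higher numbers for a weaker effect at the one concentration tested), where compound 1 gives 37%. That places it second highest of the three numbers. Its nearest neighbour is compound 3 `CCCCCCCCCCCCCCCCc1nc(N2CCC2)c(C)c(C)c1O`, which in this assay gives 38%, a number within the usual scatter of compound 1. Furthest away is compound 2 `CCCCCCCCCCc1c(C)c(N(C)C)nc(C)c1O`, which gives 2%.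

For the measured compounds named here, only one single-point step has been measured: a number 35 percentage points lower from compound 1 to compound 2 (beyond the scatter), a change in the long saturated chain far from the aromatic ring.

Compound 4 `CCCCCCCCCCCCCCCCc1c(C)c(N2CCC2)nc(C)c1O` differs from compound 1 in one place: azetidin-1-yl in place of dimethylamino on an aromatic carbon. Going by the values given here, no measured step touches this amine directly, so the chain step from compound 1 to compound 2 says nothing about it. What the numbers do show is that compound 3, which also carries azetidin-1-yl on its core, gives a value within the scatter of compound 1, while both keep the same long saturated chain. On that basis the expected step is none beyond the scatter, so a number 1 percentage points higher from compound 1 to compound 4 (within the scatter) is estimated to be small. For compound 4 the value in this assay is therefore expected to be about 38%, within a range from 20% to 56%.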

Compound 4, a percentage reported as activity, at one concentration (the size of the read-out at that concentration, not a potency): 50%
For compound 4 the middle estimate is 12 percentage points below the measured one; low and high end bracket the measured number.
By their numbers in this assay, from the lowest: compound 2; then compounds 1 and 3 (each within the scatter of the next); then compound 4.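

The amine on this aromatic carbon, next to the ring nitrogen, turns out to matter for the result. Replacing the open dimethylamino with the four-membered ring of azetidin-1-yl gives, in this assay, a number 13 percentage points higher from compound 1 to compound 4 (beyond the scatter), so the effect at the one concentration tested becomes somewhat weaker. The step runs opposite in direction to the chain change, a number 35 percentage points lower from compound 1 to compound 2 (beyond the scatter), and is smaller, so both the amine and the far end of the chain can shift this read-out, and no measurement shown explains why the amine swap has this effect.

Open, going by these compounds, is whether the number follows the size of the amine ring, which a pyrrolidin-1-yl or piperidin-1-yl group at the same place could test, or whether a plain amino group would behave differently from both amines seen so far. Also open, on these data alone, is whether azetidin-1-yl would shift the number in the same way on the shorter chain of compound 2, where the value already sits much lower, at 2%.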